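A few compounds are considered here, and "the series" means these few. Any claim that something is new, unique, unknown or untested is made for them only; others in the source may bear on it.

In a functional assay on SMMC-7721 cells (Homo sapiens) for inhibition, read by MTT assay, with a stated time of 48 h (a higher number here means a weaker inhibitor, a lower number a stronger inhibitor), compound 1 `CN(c1ncccc1CNc1nc(Nc2ccc3c(c2)CC(=O)N3)nc2[nH]cc(F)c12)S(C)(=O)=O` gives 73200 nM. Compound 2 `CN(c1ncccc1CNc1nc(Nc2ccccc2)nc2[nH]cc(F)c12)S(C)(=O)=O` reads > 100000 nM, which is a limit of the assay and not a number. For the measured compounds named here, compound 3 `CN(c1ncccc1CNc1nc(Nc2ccc(F)cc2)nc2[nH]cc(F)c12)S(C)(=O)=O` gives 27900 nM, the lowest number so far.

Compound 4 `CN(c1ncccc1CNc1nc(Nc2ccc(F)c(Cl)c2)nc2[nH]cc(F)c12)S(C)(=O)=O` follows from compound 3 by chloro in place of hydrogen on an aromatic carbon, ortho to a fluoro group and meta to a large group: chloro in place of hydrogen on an aromatic carbon. Going by the values given here, no measured step adds chloro. Among the compounds with values here, the closest precedent is fluoro in place of hydrogen on an aromatic carbon, which gave an at least 3.5-fold lower number from compound 2 to compound 3 (0.55 log units; beyond the scatter). The exchange of a whole group in a 2.6-fold lower number from compound 1 to compound 3 (0.42 log units; beyond the scatter) bears on the change less directly, though it points the same way.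

A modest further fall in this assay is therefore expected, no larger than the fluoro step and possibly within the scatter. The expected change is a 1.6-fold lower number from compound 3 to compound 4 (0.22 log units; within the scatter). Compound 4 is estimated at 17000 nM, with an expected range of 6000 nM to 50000 nM.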

Compound 4, half-maximal inhibitory concentration: > 100000 nM
Compound 4: only a limit was reported; the forecaster's own chance of this, stated with the estimate: 6%; at least 5.8-fold (0.76 log units) between middle value and limit.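

Chloro in place of hydrogen on this aromatic carbon, ortho to a fluoro group and meta to a large group, reverses the direction of the earlier halogen step in this assay: fluoro gave an at least 3.5-fold lower number from compound 2 to compound 3 (0.55 log units; beyond the scatter) and chloro gives an at least 3.5-fold higher number from compound 3 to compound 4 (0.55 log units; beyond the scatter). The comparison with the larger group of compound 1 gives an at least 1.3-fold higher number from compound 1 to compound 4 (0.13 log units; that floor lies within the scatter) and sets no order between those two compounds, since its floor lies within the scatter. The reading of compound 4 is a limit of the assay and not a number, as is that of compound 2, so the step between them cannot be read: the limit of > 100000 nM in this assay, at which 2 of the 4 values shown sit.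

As far as these compounds go, whether a methyl or methoxy group on the same carbon would behave as chloro does remains open, as does the effect of chloro without the fluoro group, as in 3-chlorophenyl. How far compound 2 and compound 4 lie past the limit is also unknown.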